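Notes on the step from compound 3 to compound 4

The compounds below may be only part of what the source reports. "The series", "measured", "known", "first", "only" and "open" are said of these compounds alone.

- compound 1 `COc1cc2c(Nc3ccc(C#N)cc3)ncnc2cc1OCCCN(C)C`: > 100000 nM (a limit)
- compound 2 `COc1cc2c(Nc3ccc(C#N)cc3)ncnc2cc1OCCCN(C)Cc1ccccc1`: > 100000 nM (a limit)
- compound 3 `CCOC(=O)C1CCN(CCCOc2cc3ncnc(Nc4ccc(C#N)cc4)c3cc2OC)CC1`: 57700 nM

For the measured compounds named here, in a functional assay on HepG2 cells (Homo sapiens) for antiproliferative activity, read by MTT assay, with a stated time of 72 h (a higher number here means a weaker inhibitor, a lower number a stronger inhibitor), compound 3 gives 57700 nM, the only actual number in the set. The other two entries stand at the limit of > 100000 nM in this assay, at which 2 of the 3 values shown sit.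

Compound 4 `COc1cc2c(Nc3ccc(C#N)cc3)ncnc2cc1OCCCN1CCC(N(C)C)CC1` carries dimethylamino in place of ethoxycarbonyl on a saturated ring carbon. The same difference reads 4-(ethoxycarbonyl)piperidin-1-yl to 4-(dimethylamino)piperidin-1-yl.

Going by the values given here, no measured step makes this exact change. The nearest evidence is an at least 1.7-fold lower number from compound 1 to compound 3 (0.23 log units; that floor lies within the scatter) and an at least 1.7-fold lower number from compound 2 to compound 3 (0.23 log units; that floor lies within the scatter), both changes at the same chain end, and both only floors. The step that the two limits leave unreadable from compound 1 to compound 2 adds nothing. Compound 1, which also carries dimethylamino, stands at > 100000 nM, a limit. In this assay no change beyond the scatter is therefore expected, with a lean towards a higher number and a real chance of reaching the limit. The expected step is a 1.2-fold higher number from compound 3 to compound 4 (0.08 log units; within the scatter). For compound 4 the estimate is 70000 nM, with an expected range of 25000 nM to 100000 nM.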

Compound 4, half-maximal inhibitory concentration: 33600 nM
Compound 4: middle estimate off by 2.1-fold (0.32 log units), on the high side, and the stated range covers the measured number.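

In this assay, dimethylamino in place of ethoxycarbonyl on the saturated ring carbon gives a 1.7-fold lower number from compound 3 to compound 4 (0.23 log units; within the scatter), so the two groups cannot be told apart at this place. The new information lies at the chain end: the 4-(dimethylamino)piperidin-1-yl end gives an at least 2.9-fold lower number from compound 1 to compound 4 (0.47 log units; beyond the scatter) and an at least 2.9-fold lower number from compound 2 to compound 4 (0.47 log units; beyond the scatter), and unlike the floors for compound 3, these floors lie beyond the scatter. Dimethylamino on the ring carbon of compound 4 therefore gives a measured number, while the same group directly on the chain in compound 1 does not, as that entry is a limit.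

The compounds shown leave open how a plain piperidin-1-yl end or a morpholin-4-yl end would stand. They also leave open whether a carboxylic acid in place of ethoxycarbonyl, or a longer chain, would shift the number.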